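Swapping the aryl group on the amide of an mGlu5 modulator

A few compounds are considered here, and "the series" means these few. Any claim that something is new, unique, unknown or untested is made for them only; others in the source may bear on it.

Of the compounds shown here, three sharing one core have been measured in an assay on HEK293 cells for positive allosteric modulation of metabotropic glutamate receptor 5 (Homo sapiens), read by FLIPR, with a stated time of 1 h; on this read-out lower numbers stand for an effect already at smaller amounts and higher numbers for an effect only at larger amounts of compound. Compound 1 `O=C(C1CC12CCC2)N1CCc2nc(C#Cc3ccccc3)sc2C1` gives 3.9 nM. Compound 2 `O=C(CC1CCOCC1)N1CCc2nc(C#Cc3ccccc3)sc2C1` gives 470 nM. Compound 3 `O=C(c1cccc(Cl)c1)N1CCc2nc(C#Cc3ccccc3)sc2C1` gives 8.7 nM, the second highest of the three numbers: it lies a small distance from compound 1, as a 2.2-fold higher number from compound 1 to compound 3 (0.35 log units; beyond the scatter) shows, and far from compound 2, as a 54-fold lower number from compound 2 to compound 3 (1.73 log units; beyond the scatter) shows. Both steps change only the group on the carbonyl carbon, and together they show that this position can move the number a great deal or only a little.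

Compound 4 `Cc1cccc(C(=O)N2CCc3nc(C#Cc4ccccc4)sc3C2)n1` differs from compound 3 in exactly that place: 6-methylpyridin-2-yl in place of 3-chlorophenyl on a carbonyl carbon. For the measured compounds named here, no measured pair exchanges one aromatic ring for another aromatic ring with a ring nitrogen, so the measured steps set only a rough frame. Because a 2.2-fold higher number from compound 1 to compound 3 (0.35 log units; beyond the scatter) was modest for a large structural change, a small step is expected here, with no firm direction; the estimated step is a 1.7-fold higher number from compound 3 to compound 4 (0.24 log units; within the scatter). Compound 4 is therefore expected to give about 15 nM in this assay, within a range from 3 nM to 80 nM.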

Compound 4, half-maximal effective concentration: 160 nM
Beside the measured number, compound 4's estimate is 11-fold (1.03 log units) below it; measured number above the stated range.
By their numbers in this assay, from the lowest: compound 1; then compound 3; then compound 4; then compound 2.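

In this assay there is an 18-fold higher number from compound 3 to compound 4 (1.26 log units; beyond the scatter) when 6-methylpyridin-2-yl replaces 3-chlorophenyl, so a six-membered aromatic ring on the carbonyl carbon does not by itself keep the number low. The new ring falls much closer to the (oxan-4-yl)methyl group, with a 2.9-fold lower number from compound 2 to compound 4 (0.47 log units; beyond the scatter) set against a 41-fold higher number from compound 1 to compound 4 (1.61 log units; beyond the scatter) on the other side, so one exchange of aromatic rings here can span most of the spread seen at this position. Nothing available explains the size of this step.

Going by these compounds, the exchange alters the ring nitrogen, the methyl group and the chlorine all at once, so which of them carries the step stays open. Also open, on these data alone, is where a plain pyridin-2-yl or an unsubstituted phenyl would fall on the same carbonyl carbon.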